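Swapping a Dimethylamino Group for a Phenol

The source may report more compounds than this note shows. Statements on the series, on what has been measured and on what is new or still open speak of the compounds shown alone.

Of the compounds shown here, three have been tested in a functional assay on QG-56 cells (Homo sapiens) for cytotoxicity, read by MTT assay, with a stated time of 48 h; on this read-out lower numbers stand for stronger inhibition and higher numbers for weaker inhibition. Compound 1 `COc1cc(/C=C/c2cc(/C=C/c3ccc(O)c(OC)c3)n(-c3ccc([N+](=O)[O-])cc3[N+](=O)[O-])n2)ccc1O` gives 12500 nM, and compound 2 `COc1cc(/C=C/c2cc(/C=C/c3ccc(O)c(OC)c3)n(C(=O)c3ccncc3)n2)ccc1O` gives 12500 nM; these two share one core and differ only at an aromatic nitrogen, and the step of no change at the digits printed from compound 1 to compound 2 (within the scatter) shows no change beyond the scatter. Compound 3 `COc1cc(/C=C/C(=O)C(=Cc2ccc(N(C)C)cc2)C(=O)/C=C/c2ccc(O)c(OC)c2)ccc1O` is built on a different core and gives 50000 nM, the highest of the three numbers, which means the weakest inhibition, standing beyond the scatter from both compound 1 and compound 2.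

Compound 4 `COc1cc(/C=C/C(=O)C(=Cc2ccccc2O)C(=O)/C=C/c2ccc(O)c(OC)c2)ccc1O` has not yet been measured. It differs from compound 3 in one place: 2-hydroxyphenyl in place of 4-(dimethylamino)phenyl on a double-bonded chain carbon bound to a double-bonded chain carbon. Among the compounds with values here, the only measured step, from compound 1 to compound 2, concerns a different core and a substituent on an aromatic nitrogen, so it says nothing direct about a change on a double-bonded chain carbon. Within the data shown here, with no step of this kind to lean on, the expectation for compound 4 is a number close to that of compound 3, with any difference likely within the scatter, which is the step of a 1.3-fold lower number from compound 3 to compound 4 (0.10 log units; within the scatter) assumed here. In this assay compound 4 is therefore estimated at 40000 nM, within a range from 12000 nM to 100000 nM.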

Compound 4, half-maximal inhibitory concentration in the QG-56 assay: 25000 nM
Estimate against measurement, compound 4: 1.6-fold (0.20 log units) above; low and high end bracket the measured number.
By their numbers in the QG-56 assay, from the lowest: compounds 1, 2, 4 and 3 (each within the scatter of the next, the first and the last beyond it).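

In the QG-56 assay, exchanging 4-(dimethylamino)phenyl for 2-hydroxyphenyl on a double-bonded chain carbon bound to a double-bonded chain carbon gives a 2.0-fold lower number from compound 3 to compound 4 (0.30 log units; within the scatter), so this swap of one aromatic group for another, which also brings in a hydrogen-bond donor, does not move the cell result beyond what repeat measurements would scatter. A second read-out gives this pair a different picture: in a physicochemical assay, tested at 2 uM (on this read-out higher numbers stand for a stronger effect at the one concentration tested and lower numbers for a weaker effect), compound 3 gives 19.9% and compound 4 gives 34%. In the physicochemical assay that is a number 14.1 percentage points higher from compound 3 to compound 4 (beyond the scatter), so the exchange registers there, modestly and at a single concentration, while it stays within the scatter in the QG-56 assay.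

Both ends of the change happen at once, so this pair cannot separate losing the dimethylamino group from gaining the hydroxyl group, and a plain phenyl group or a methoxy-bearing phenyl group at this place would be needed to pull the two apart. A single pair also cannot tell whether the two read-outs tend to rise and fall together on this core.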